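This account rests on a few compounds, and the source may have more. Where it says the series, first, only, none or still open, it means among the compounds named here.

Of the compounds shown here, three of a shared core have been measured in a functional assay on HCT-116 cells (Homo sapiens) for antiproliferative activity, read by MTT assay, with a stated time of 72 h (on this read-out lower numbers stand for stronger inhibition and higher numbers for weaker inhibition), and they differ only in the group carried on one carbon of the triazole-type ring. Compound 1 `COc1ccccc1-c1cn(C[C@H](O)[C@H]2OC(=O)C(OCc3ccccc3)=C2OCc2ccccc2)nn1` carries a 2-methoxyphenyl group there; in this assay compound 1 reaches only the limit of the measurement, > 100000 nM, which is a boundary rather than a number (the limit of > 100000 nM in this assay, at which 1 of the 3 values shown sits). Compound 2 `CCCCCCCCCCc1cn(C[C@H](O)[C@H]2OC(=O)C(OCc3ccccc3)=C2OCc2ccccc2)nn1` carries a decyl chain instead and in this assay gives 28800 nM, a change of an at least 3.4-fold lower number from compound 1 to compound 2 (0.54 log units; beyond the scatter). Compound 3 `O=C1O[C@H]([C@@H](O)Cn2cc(C3CC3)nn2)C(OCc2ccccc2)=C1OCc1ccccc1` carries a cyclopropyl group and in this assay gives 30400 nM, a change of an at least 3.2-fold lower number from compound 1 to compound 3 (0.51 log units; beyond the scatter). Between the two compounds with a measured number, the difference is a 1.1-fold higher number from compound 2 to compound 3 (0.02 log units; within the scatter), so compound 3 and compound 2 cannot be told apart here, although compound 3 holds the higher of the two numbers.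

Compound 4 `COc1ccc(-c2cn(C[C@H](O)[C@H]3OC(=O)C(OCc4ccccc4)=C3OCc3ccccc3)nn2)cc1` has not yet been measured in this assay. It differs from compound 3 in one place: 4-methoxyphenyl in place of cyclopropyl on an aromatic carbon. Within the data shown here, the step that bears on this is the one from compound 1 to compound 3, where a methoxyphenyl group gave way to cyclopropyl and the number fell by at least a modest amount. Compound 4 reverses that kind of change, so a rise in the number is expected, plausibly back toward the limit. For compound 4 the estimate is 90000 nM, with a likely range from 25000 nM to 300000 nM, meaning an expected step of a 3.0-fold higher number from compound 3 to compound 4 (0.47 log units; beyond the scatter).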

Compound 4, half-maximal inhibitory concentration: > 100000 nM
Compound 4 ended at the assay's limit; the forecaster's own chance of this, stated with the estimate: 45%; at least 1.1-fold (0.04 log units) between middle value and limit.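

Replacing cyclopropyl with 4-methoxyphenyl gives an at least 3.2-fold higher number from compound 3 to compound 4 (0.51 log units; beyond the scatter), and replacing decyl with it gives an at least 3.4-fold higher number from compound 2 to compound 4 (0.54 log units; beyond the scatter), so in this assay the poor result seen with 2-methoxyphenyl is not confined to that one group. Compound 4 gives > 100000 nM, which is a limit of the assay and not a number. Across these four compounds, both methoxyphenyl groups sit at that limit while decyl and cyclopropyl give measured numbers, with no compound going against this, but the step between the two methoxyphenyl compounds cannot be read, so they cannot be ranked against each other: the limit of > 100000 nM in this assay, at which 2 of the 4 values shown sit.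

The compounds shown do not separate the phenyl ring from its methoxy group, and an unsubstituted phenyl, or a phenyl carrying a hydroxyl or an amine, would help to tell which of the two goes with the loss. They also leave open how far the non-aromatic side of this position can be pushed, since decyl and cyclopropyl lie within the scatter of each other and a butyl or hexyl chain, or a chain ending in an amine, could show whether any group here does better.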